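Swapping Fluoro for Cyano on the Aryl Ether

A few compounds are considered here, and "the series" means these few. Any claim that something is new, unique, unknown or untested is made for them only; others in the source may bear on it.

Of the compounds shown here, three have been measured in an assay on HEK293 cells for agonist activity at transient receptor potential cation channel subfamily M member 8 (Homo sapiens), read by fluorescence and calcium flux, with a stated time of 15 min; on this read-out lower numbers stand for an effect already at smaller amounts and higher numbers for an effect only at larger amounts of compound. Compound 1 `Cc1ccc(OCC(=O)N(Cc2cccs2)c2cnn(C)c2)cc1` gives 63000 nM in this assay. For the measured compounds named here, compound 3 `Cc1ccc(OCC(=O)N(Cc2cccs2)c2nccs2)cc1` gives 2240 nM; the one step between measured compounds that differ in a single place, a 28-fold lower number from compound 1 to compound 3 (1.45 log units; beyond the scatter), concerns only the group on the amide-type nitrogen. Compound 2 `CCN(Cc1cccs1)C(=O)COc1ccc(F)cc1` gives 422 nM, the lowest of the three numbers; compound 3 is its nearest neighbour and compound 1 its most distant one, and both lie beyond the usual scatter from it.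

Compound 4 `CCN(Cc1cccs1)C(=O)COc1ccc(C#N)cc1` differs from compound 2 in one place: cyano in place of fluoro on an aromatic carbon. Going by the values given here, the six-membered aromatic ring of carbon only that carries this group is left untouched by every measured step, because a 28-fold lower number from compound 1 to compound 3 (1.45 log units; beyond the scatter) changes the amide nitrogen instead. Among the compounds with values here, no measured step therefore bears on the exchange of fluoro for cyano, and the three numbers give no direction for it. The expectation is a step of modest size, a 1.4-fold higher number from compound 2 to compound 4 (0.15 log units; within the scatter), which could well fall inside the scatter. Compound 4 is estimated at 600 nM in this assay, with a range from 150 nM to 2500 nM.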

Compound 4, half-maximal effective concentration: 1990 nM
Compound 4: the middle estimate sits 3.3-fold (0.52 log units) below what was measured, within the range that was stated.
By their numbers in this assay, from the lowest: compound 2; then compounds 4 and 3 (each within the scatter of the next); then compound 1.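

For the compounds shown here, this is the first measured change on the six-membered aromatic ring, and it shows that the place para to a large group is not indifferent to what sits there: in this assay, cyano in place of fluoro gives a 4.7-fold higher number from compound 2 to compound 4 (0.67 log units; beyond the scatter). The number moves beyond the scatter, so for this pair fluoro is the better fit of the two groups if a lower number is the aim. The count of what changed is simple, with two heavy atoms entering for one and one hydrogen-bond acceptor entering where fluoro counts none, but no measurement shown links either difference to the higher number.

From the compounds shown here alone, a single pair gives no trend, so it remains open how a chlorine atom, a methoxy group, an amine or a plain hydrogen at this place would compare with fluoro and cyano. Going by these compounds, it is also open whether the same exchange would give a step of similar size with 1,3-thiazol-2-yl or 1-methyl-1H-pyrazol-4-yl on the amide-type nitrogen, in place of the ethyl group that compound 2 and compound 4 share.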